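Swapping a Vinyl Tail for a Hydroxyethyl One

The source may report more compounds than this note shows. Statements on the series, on what has been measured and on what is new or still open speak of the compounds shown alone.

Compound 1 `C=CCO/N=C/c1c(N)ncnc1Oc1ccc(NC(=O)C2(C(=O)Nc3ccc(F)cc3)CC2)cc1F` gives 3.65 in a physicochemical assay for lipophilicity, using the shake flask method; on this read-out lower numbers stand for lower lipophilicity and higher numbers for higher lipophilicity. Compound 2 `CCO/N=C/c1c(N)ncnc1Oc1ccc(NC(=O)C2(C(=O)Nc3ccc(F)cc3)CC2)cc1F` gives 3.41 in this assay, and the step of a number 0.24 log units lower from compound 1 to compound 2 (within the scatter) comes from methyl in place of vinyl on a saturated chain carbon bound to an oxygen on an unsaturated carbon. Compound 3 `Nc1ncnc(Oc2ccc(NC(=O)C3(C(=O)Nc4ccc(F)cc4)CC3)cc2F)c1/C=N/OCCCO` differs from compound 1 by 2-hydroxyethyl in place of vinyl on a saturated chain carbon bound to an oxygen on an unsaturated carbon. For the measured compounds named here, no measured step brings in a hydrogen-bond donor and acceptor, so the vinyl-to-methyl step is only a loose guide. Compound 3 is expected to read 2.5, between 1.9 and 3.1, an expected move of a number 1.15 log units lower from compound 1 to compound 3 (beyond the scatter) beyond the scatter.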

Compound 3, partition coefficient: 2.67
The estimate for compound 3 lay 0.17 log units below the measured number; the measured number falls inside the stated range.
By their numbers in this assay, from the lowest: compound 3; then compounds 2 and 1 (each within the scatter of the next).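

In this assay, for the compounds shown here, this position proves able to shift the number clearly: replacing vinyl with 2-hydroxyethyl gives a number 0.98 log units lower from compound 1 to compound 3 (beyond the scatter) and so goes further than the only earlier step, which stayed within the scatter. Adding hydroxymethyl in place of hydrogen on the saturated tail of the ethyl compound gives a number 0.74 log units lower from compound 2 to compound 3 (beyond the scatter) and also exceeds the scatter. No available measurement accounts for the size of these steps. Still open, from the compounds shown here alone, is how an amine, a carboxylic acid or a longer chain carrying a terminal hydroxyl would read at this place.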